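This account rests on a few compounds, and the source may have more. Where it says the series, first, only, none or still open, it means among the compounds named here.

Of the compounds shown here, three built on one shared core have been measured in an ADME assay on microsomes from liver (Mus musculus) for metabolic stability, read by LC-MS, using NADPH, with a stated time of 10 min, tested at 0.1 uM; a higher number here means faster removal of the compound, a lower number slower removal. Compound 1 `O=C(NCCCCc1ccccc1)c1cccc(C2SCC(=O)N2c2ccccn2)c1` gives 644 mL.min-1.g-1. Compound 2 `O=C(NCCCCc1ccccc1)c1cccc(C2SCC(=O)N2c2ccc(C3CC3)cc2)c1` gives 2960 mL.min-1.g-1, and compound 3 `COc1ccc(F)cc1N1C(=O)CSC1c1cccc(C(=O)NCCCCc2ccccc2)c1` gives 2250 mL.min-1.g-1. Compound 3 therefore stands second highest of the three numbers: the step of a 1.3-fold lower number from compound 2 to compound 3 (0.12 log units; within the scatter) lies within the scatter, whereas compound 1 is set apart by a 3.5-fold higher number from compound 1 to compound 3 (0.54 log units; beyond the scatter) and by a 4.6-fold higher number from compound 1 to compound 2 (0.66 log units; beyond the scatter).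

Compound 4 `Cc1cccc(N2C(=O)CSC2c2cccc(C(=O)NCCCCc3ccccc3)c2)c1` differs from compound 3 in one place: 3-methylphenyl in place of 5-fluoro-2-methoxyphenyl on an amide-type nitrogen in a ring. All three measured steps concern this same position on the amide-type nitrogen in the ring. The two steps that replaced pyridin-2-yl with a six-membered aromatic ring of carbon only were modest and both upward; the step between the two carbon-only rings stayed within the scatter. Among the compounds with values here, compound 4 carries a six-membered aromatic ring of carbon only, as do compound 2 and compound 3, and nothing among the measured compounds shows that a 3-methylphenyl group behaves differently from those two. Compound 4 is therefore expected to show only a small step, a 1.1-fold higher number from compound 3 to compound 4 (0.05 log units; within the scatter), with no direction beyond the scatter predicted. Compound 4 is estimated at 2500 mL.min-1.g-1 in this assay, within a range from 1200 mL.min-1.g-1 to 5200 mL.min-1.g-1.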

Compound 4, intrinsic clearance in microsomes: 2940 mL.min-1.g-1
Estimate against measurement, compound 4: 1.2-fold (0.07 log units) below; the measured number falls inside the stated range.
By their numbers in this assay, from the lowest: compound 1; then compounds 3, 4 and 2 (each within the scatter of the next).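

In this assay, moving to 3-methylphenyl gives a 1.3-fold higher number from compound 3 to compound 4 (0.12 log units; within the scatter) and a 1.0-fold lower number from compound 2 to compound 4 (0.00 log units; within the scatter); both steps lie within the scatter, so a third carbon-only aromatic ring on the amide-type nitrogen joins the other two, even though the entering group has no oxygen or fluorine and no hydrogen-bond acceptor. The contrast with pyridin-2-yl holds as well, with a 4.6-fold higher number from compound 1 to compound 4 (0.66 log units; beyond the scatter), so all three carbon-only rings, each with different substituents, now stand apart from compound 1 by a modest step beyond the scatter. Nothing measured here accounts for that gap.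

The compounds shown leave open whether the ring nitrogen of pyridin-2-yl itself sets compound 1 apart, and whether a pyridin-3-yl group, or an amine or a carboxylic acid on the carbon-only ring, would bring the number towards that of compound 1. On these data alone, they also change only this one position, so the effect of a shorter chain on the amide nitrogen in this assay remains open.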